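Shifting the aryl group of compound 3: ethoxyphenyl enters

This account rests on a few compounds, and the source may have more. Where it says the series, first, only, none or still open, it means among the compounds named here.

Compound 1 `CC(C)C[C@H](N)c1cc(C(F)(F)F)ccc1N1CCN(C(=O)[C@H](C)Cc2ccc(Cl)cc2)CC1` gives 31 nM in an assay on HEK293 cells for displacement of a labelled ligand from Melanocortin receptor 4 (Homo sapiens); on this read-out higher numbers stand for weaker inhibition and lower numbers for stronger inhibition.
Compound 2 `CC(C)C[C@H](N)c1cc(C(F)(F)F)ccc1N1CCN(C(=O)CCNC2CCCCC2)CC1` gives 4800 nM in this assay.
Compound 3 `Cc1cc(CC(C)C(=O)N2CCN(c3ccc(C(F)(F)F)cc3[C@@H](N)CC(C)C)CC2)ccc1Cl` gives 71 nM in this assay.

Compound 3 stands second highest of the three numbers; its nearest neighbour is compound 1, with a 2.3-fold higher number from compound 1 to compound 3 (0.36 log units; beyond the scatter), and its furthest is compound 2, with a 68-fold lower number from compound 2 to compound 3 (1.83 log units; beyond the scatter). The step to the unmeasured compound 4 `CCOc1cccc(CC(C)C(=O)N2CCN(c3ccc(C(F)(F)F)cc3[C@@H](N)CC(C)C)CC2)c1` is 3-ethoxyphenyl in place of 4-chloro-3-methylphenyl on a saturated chain carbon, two bonds along the chain from a carbonyl carbon.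

Within the data shown here, no measured step covers an ethoxy group on this aryl ring. The steps that do bear on the region are a 2.3-fold higher number from compound 1 to compound 3 (0.36 log units; beyond the scatter), a modest move for adding a methyl beside the existing chlorine, and a 150-fold higher number from compound 1 to compound 2 (2.19 log units; beyond the scatter), a large loss when the whole aryl unit gives way to a saturated amine chain. Among the measured compounds shown here, compound 4 keeps the aromatic ring, so the large loss seen for compound 2 is not expected to recur, but the chlorine and methyl are both exchanged at once, which is a wider change than the one from compound 1 to compound 3. A modest weakening, possibly beyond the scatter, is therefore expected: a 2.3-fold higher number from compound 3 to compound 4 (0.35 log units; beyond the scatter). For compound 4 the estimated value in this assay is 160 nM, with a range from 40 nM to 650 nM.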

Compound 4, inhibition constant: 2200 nM
Compound 4: middle estimate off by 14-fold (1.14 log units), on the low side, outside the stated range (above it).
By their numbers in this assay, from the lowest: compound 1; then compound 3; then compound 4; then compound 2.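

In this assay, the exchange of 4-chloro-3-methylphenyl for 3-ethoxyphenyl on this saturated chain carbon proves far more costly than the earlier change to this aryl ring, the added methyl (a large step: a 31-fold higher number from compound 3 to compound 4 (1.49 log units; beyond the scatter); and measured against the unmethylated chlorinated ring: a 71-fold higher number from compound 1 to compound 4 (1.85 log units; beyond the scatter)). Keeping an aromatic ring at this place therefore does not by itself hold the number, since the 3-ethoxybenzyl unit ends up much nearer the saturated amine chain than either chlorinated unit does, though it remains a modest step better than that chain (the step: a 2.2-fold lower number from compound 2 to compound 4 (0.34 log units; beyond the scatter)). Nothing available gives a reason for this loss.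

The chlorine and the methyl leave together here and the ethoxy arrives in the same step, so the compounds shown cannot say how much of the loss belongs to each part of the change. On these data alone, that remains open for a ring that keeps the chlorine and carries the ethoxy as well, and for a methoxy group in place of the ethoxy.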